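Sulfonamide aryl variation: from compound 3 to compound 4

The compounds below may be only part of what the source reports. "The series", "measured", "known", "first", "only" and "open" are said of these compounds alone.

Compound 3 `O=C1NCCN1c1ccc(S(=O)(=O)Nc2cccc(Br)c2)cc1` gives 110 nM in a functional assay on CCRF-CEM cells (Homo sapiens) for antiproliferative activity, read by sulforhodamine B assay, with a stated time of 48 h (on this read-out higher numbers stand for weaker inhibition and lower numbers for stronger inhibition), the lowest of the three numbers shown. Compound 2 `Cc1cccc(NS(=O)(=O)c2ccc(N3CCNC3=O)cc2)c1` gives 200 nM, within the scatter of compound 3, while compound 1 `O=C1NCCN1c1ccc(S(=O)(=O)Nc2ccc3[nH]ccc3c2)cc1` gives 410 nM, beyond it. Among the measured compounds shown here, the only measured step that bears on the aryl group of the sulfonamide is a 1.8-fold lower number from compound 2 to compound 3 (0.26 log units; within the scatter). Compound 4 `Cc1ccc(C)c(NS(=O)(=O)c2ccc(N3CCNC3=O)cc2)c1` differs from compound 3 by 2,5-dimethylphenyl in place of 3-bromophenyl on a sulfonamide nitrogen. For the measured compounds named here, the comparison of compound 2 with compound 3 suggests little movement on swapping bromo for methyl, and no measured pair speaks to the second methyl. The number for compound 4 is therefore expected at about 200 nM, with a range of 90 nM to 450 nM, a step of a 1.8-fold higher number from compound 3 to compound 4 (0.26 log units; within the scatter) that remains within the scatter.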

Compound 4, half-maximal inhibitory concentration: 74 nM
Beside the measured number, compound 4's estimate is 2.7-fold (0.43 log units) above it, and the stated range ends above it.
By their numbers in this assay, from the lowest: compounds 4, 3 and 2 (each within the scatter of the next, the first and the last beyond it); then compound 1.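

The aryl group on the sulfonamide nitrogen accepts 2,5-dimethylphenyl in place of 3-bromophenyl without a separable difference (a 1.5-fold lower number from compound 3 to compound 4 (0.17 log units; within the scatter)). Among the compounds shown here, the added methyl on an aromatic carbon gives the first single-place step in this aryl group that lies beyond the scatter, though a modest one (a 2.7-fold lower number from compound 2 to compound 4 (0.43 log units; beyond the scatter)). Nothing available explains either step.

Still open, on these data alone, is whether an amine or a carboxylic acid on this aryl ring would fit the same trend. As far as these compounds go, whether a longer chain in place of methyl would hold these numbers also remains open.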